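Carbamate to difluoroethyl acyl on the piperidine series

A few compounds are considered here, and "the series" means these few. Any claim that something is new, unique, unknown or untested is made for them only; others in the source may bear on it.

Compound 1 `Cc1nc(S(C)(=O)=O)ccc1Oc1ncnc(OC2CCN(C(=O)OC(C)C)CC2)c1F`: 77%
Compound 2 `Cc1nc(S(C)(=O)=O)ccc1Oc1ncnc(OC2CCN(C(=O)OC3CCC3)CC2)c1F`: 81%
Compound 3 `CCC1(OC(=O)N2CCC(Oc3ncnc(Oc4ccc(S(C)(=O)=O)nc4C)c3F)CC2)CC1`: 83%

In a functional assay on isolated protein for inhibition of Glucose-dependent insulinotropic receptor (Rattus norvegicus), read by HTRF and cAMP accumulation (a lower number here means a smaller maximal response, a higher number a larger maximal response), compound 3 gives 83%, the highest of the three numbers, though the steps of a number 2 percentage points higher from compound 2 to compound 3 (within the scatter) and a number 6 percentage points higher from compound 1 to compound 3 (within the scatter) both lie within the scatter, as does a number 4 percentage points higher from compound 1 to compound 2 (within the scatter).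

Compound 4 `Cc1nc(S(C)(=O)=O)ccc1Oc1ncnc(OC2CCN(C(=O)C(C)(F)F)CC2)c1F` differs from compound 3 by a group of 4 heavy atoms (2 carbon, 2 fluorine; no ring) in place of a group of 6 heavy atoms (5 carbon, 1 oxygen; one three-membered non-aromatic ring of carbon only), on a carbonyl carbon. For the measured compounds named here, all three measured steps change only the group on the oxygen of the carbamate; none alters the carbonyl carbon itself, so no step bears directly on this change. Those steps were all small. Compound 4 is therefore expected to stay close, with an estimated step of a number 7 percentage points lower from compound 3 to compound 4 (within the scatter), and compound 4 is estimated at 76% in this assay, ranging from 60% to 90%.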

Compound 4, largest response reached (reported as efficacy), in percent of the reference or control that the assay uses: 87%
For compound 4 the middle estimate is 11 percentage points below the measured one; measured number inside the range.
By their numbers in this assay, from the lowest: compounds 1, 2, 3 and 4 (each within the scatter of the next).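

In this assay the carbamate oxygen can go from this carbonyl carbon, with 1,1-difluoroethyl taking the place of the whole alkoxy group, and the result is a number 4 percentage points higher from compound 3 to compound 4 (within the scatter) and a number 6 percentage points higher from compound 2 to compound 4 (within the scatter) and a number 10 percentage points higher from compound 1 to compound 4 (within the scatter) with no step beyond the scatter. For the compounds shown here, the earlier steps changed only the group on that oxygen, so this is the first sign that an acyl group without the oxygen holds the maximal response. Nothing available explains this result.

Going by these compounds, whether an unfluorinated ethyl group or trifluoromethyl on the same carbonyl carbon would behave alike stays open. So does the effect of an amine there.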